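The source may hold more compounds than are shown below. What is called first, only, known or untested is meant among the compounds shown, and "the series" means these compounds.

For the measured compounds named here, in a functional assay on LOX IMVI cells (Homo sapiens) for inhibition, read by sulforhodamine B assay, with a stated time of 48 h (a higher number here means a weaker inhibitor of growth, a lower number a stronger inhibitor of growth), compound 2, whose structure is `COc1cc(-c2nn(-c3cccc(NC(=O)c4cccc(C(F)(F)F)c4)c3)cc2-c2ccncc2)ccc1Cl`, gives 1390 nM, the highest of the three numbers measured so far, though its gaps to both neighbours stay within the scatter. Going by the values given here, compound 1, with the structure `COc1cc(-c2nn(-c3cccc(NC(=O)Nc4cc(C(F)(F)F)cc(C(F)(F)F)c4)c3)cc2-c2ccncc2)ccc1Cl`, gives 783 nM, and compound 3, with the structure `O=C(Nc1cccc(-n2cc(-c3ccncc3)c(-c3ccc(Cl)c(O)c3)n2)c1)Nc1cc(C(F)(F)F)cc(C(F)(F)F)c1`, gives 712 nM; the one step that is recorded, a 1.1-fold lower number from compound 1 to compound 3 (0.04 log units; within the scatter), changes nothing of note. Compound 4, whose structure is `COc1cc(-c2nn(-c3cccc(NC(=O)Nc4ccc(Cl)c(C(F)(F)F)c4)c3)cc2-c2ccncc2)ccc1Cl`, is obtained from compound 2 by the change ((4-chloro-3-(trifluoromethyl)phenyl)amino in place of 3-(trifluoromethyl)phenyl on a carbonyl carbon). Among the compounds with values here, no recorded step follows this exact change, and compounds 1 and 2, which differ in this region but also elsewhere, show numbers within the scatter of each other. The expectation is therefore a step of a 1.6-fold lower number from compound 2 to compound 4 (0.21 log units; within the scatter) toward a somewhat lower number, but not clearly beyond the scatter. The estimate for compound 4 in this assay is accordingly 850 nM, expected to fall between 300 nM and 2500 nM.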

Compound 4, concentration for 50% growth inhibition: 1170 nM
Compound 4: the middle estimate sits 1.4-fold (0.14 log units) below what was measured; the range from low to high includes it.
By their numbers in this assay, from the lowest: compounds 3, 1, 4 and 2 (each within the scatter of the next).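

In this assay, for the compounds shown here, the change to (4-chloro-3-(trifluoromethyl)phenyl)amino in place of 3-(trifluoromethyl)phenyl on a carbonyl carbon gives a 1.2-fold lower number from compound 2 to compound 4 (0.07 log units; within the scatter) and is the first step that can be read at this place, since the earlier step concerned only the oxygen on the aromatic ring. The entering group brings a nitrogen and a chlorine at once, and together they leave the number within the scatter, so this single step cannot separate their shares. Nothing given here explains the result.

Still open, on these data alone, is whether a carboxylic acid or a morpholine on the aromatic ring of the entering group would give a step beyond the scatter. Also open, as far as these compounds go, is whether this change reads the same on the core of compound 3, which carries hydrogen in place of that methyl.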